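Trimming a Long Ether Chain Down to Methyl

The compounds below may be only part of what the source reports. "The series", "measured", "known", "first", "only" and "open" are said of these compounds alone.

Of the compounds shown here, three built on one shared core have been tested in a functional assay on HepG2 cells (Homo sapiens) for antiproliferative activity, read by MTT assay, with a stated time of 48 h; a lower number here means a stronger inhibitor, a higher number a weaker inhibitor. Compound 1 `CCCCCCCCCCCCOc1ccc(C(=O)/C=C/c2c(/C=C/c3ccc(OC)cc3)cc(OC)cc2OC)cc1` gives 11.6 ug/mL. Compound 2 `CCCC(C)Oc1ccc(C(=O)/C=C/c2c(/C=C/c3ccc(OC)cc3)cc(OC)cc2OC)cc1` gives 11.1 ug/mL, the second highest of the three numbers; compound 1 stands nearest to it, and compound 3 `COc1ccc(/C=C/c2cc(OC)cc(OC)c2/C=C/C(=O)c2ccccc2C)cc1`, which gives 5.3 ug/mL, stands furthest from it. The step of a 1.0-fold lower number from compound 1 to compound 2 (0.02 log units; within the scatter) came from exchanging one chain for another on the same oxygen and stayed within the scatter, whereas the step of a 2.1-fold lower number from compound 2 to compound 3 (0.32 log units; beyond the scatter) came from replacing the whole ring on the carbonyl carbon.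

Compound 4 `COc1ccc(/C=C/c2cc(OC)cc(OC)c2/C=C/C(=O)c2ccc(OC)cc2)cc1` differs from compound 2 at that same oxygen: methyl in place of 1-methylbutyl on an oxygen on an aromatic ring. Among the compounds with values here, the only measured step that bears on this kind of change is a 1.0-fold lower number from compound 1 to compound 2 (0.02 log units; within the scatter), and it was within the scatter. Compound 4 is therefore expected to show a 1.0-fold lower number from compound 2 to compound 4 (0.00 log units; within the scatter), with no step beyond the scatter. Compound 4 is estimated at 11 ug/mL, with an expected range from 5.5 ug/mL to 22 ug/mL.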

Compound 4, half-maximal inhibitory concentration: 4.9 ug/mL
For compound 4 the middle estimate is 2.2-fold (0.35 log units) above the measured one; measured number below the stated range.
By their numbers in this assay, from the lowest: compounds 4 and 3 (each within the scatter of the next); then compounds 2 and 1 (each within the scatter of the next).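

In this assay the size of the group on this oxygen does matter: methyl in place of 1-methylbutyl gives a 2.3-fold lower number from compound 2 to compound 4 (0.36 log units; beyond the scatter), and methyl in place of the dodecyl chain gives a 2.4-fold lower number from compound 1 to compound 4 (0.37 log units; beyond the scatter). The earlier step between the two larger groups stayed within the scatter. That step did not include methyl on this oxygen. With methyl on the oxygen, the 4-methoxyphenyl group on the carbonyl carbon stands level with the 2-methylphenyl group, as a 1.1-fold lower number from compound 3 to compound 4 (0.03 log units; within the scatter) stays within the scatter.

Nothing available here accounts for the shift seen with methyl. On these data alone, it also remains open where between methyl and 1-methylbutyl the number changes, which an ethyl or propyl group on this oxygen would help to locate.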